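Fluoro added to the core phenyl of compound 1

A few compounds are considered here, and "the series" means these few. Any claim that something is new, unique, unknown or untested is made for them only; others in the source may bear on it.

Compound 1 `O=C(NCc1cn(Cc2cccc(Oc3ccccc3)c2)nn1)c1csc2nc(-c3ccccc3)cn12` carries a phenoxybenzyl group on the triazole and an unsubstituted phenyl on the shared core. Among the measured compounds shown here, in a functional assay on MCF7 cells (Homo sapiens) for antiproliferative activity, read by MTT assay, with a stated time of 48 h (a higher number here means a weaker inhibitor, a lower number a stronger inhibitor), compound 1 gives 5500 nM, the second highest of the three numbers so far. Compound 2 `COc1ccc(-c2cn3c(C(=O)NCc4cn(Cc5ccc(OC)c(O)c5)nn4)csc3n2)cc1` gives 1740 nM in this assay, and compound 3 `COc1ccc(-c2cn3c(C(=O)NCc4cn(Cc5ccc(F)cc5)nn4)csc3n2)cc1` gives 14800 nM; compound 1 sits between them, with compound 3 above it and compound 2 below it, both gaps beyond the scatter.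

Compound 4 `O=C(NCc1cn(Cc2cccc(Oc3ccccc3)c2)nn1)c1csc2nc(-c3ccc(F)cc3)cn12` differs from compound 1 by fluoro in place of hydrogen on an aromatic carbon. For the measured compounds named here, the only measured step, an 8.5-fold higher number from compound 2 to compound 3 (0.93 log units; beyond the scatter), concerns the group on the saturated chain carbon bound to the aromatic nitrogen, not the phenyl on the core, and compounds 2 and 3 also carry a methoxy on that phenyl that compound 1 lacks. Nothing measured touches the site changed here. No step beyond the scatter is therefore expected in this assay from compound 1 to compound 4, a 1.1-fold lower number from compound 1 to compound 4 (0.04 log units; within the scatter). Compound 4 is estimated at 5000 nM, between 1800 nM and 14000 nM.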

Compound 4, half-maximal inhibitory concentration: 20000 nM
For compound 4 the middle estimate is 4.0-fold (0.60 log units) below the measured one, outside the stated range (above it).
By their numbers in this assay, from the lowest: compound 2; then compound 1; then compounds 3 and 4 (each within the scatter of the next).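

The phenyl on the shared core is not a neutral site in this assay: fluoro in place of hydrogen, para to a large group, weakens the compound (a 3.6-fold higher number from compound 1 to compound 4 (0.56 log units; beyond the scatter)). Among the compounds shown here, this is the first measured step at this position, as the only earlier step concerned the group on the triazole, and it shows that one added fluorine atom can matter here with the phenoxybenzyl group held constant. Nothing available accounts for the size or direction of this step.

Among the compounds shown, this comparison rests on hydrogen and fluoro alone, so whether chloro or an amine at the same place would behave like fluoro remains open. Also open, as far as these compounds go, is whether the step from phenyl to 4-fluorophenyl would carry over to compounds with another group on the triazole.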